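Working notes: cyano in place of fluoro

The source may report more compounds than this note shows. Statements on the series, on what has been measured and on what is new or still open speak of the compounds shown alone.

In a functional assay on HepG2 cells (Homo sapiens) for cytotoxicity, read by MTT assay, with a stated time of 24 h (a lower number here means a stronger inhibitor, a higher number a weaker inhibitor), compound 1 (`COc1ccc(/C=C2\CN(C)C/C(=C\c3ccccc3F)C2=O)cc1`) gives 12300 nM and compound 2 (`COc1cc(/C=C2\CN(C)C/C(=C\c3ccc(F)cc3)C2=O)cc(OC)c1`) gives 6140 nM, so compound 2 stands within the scatter of compound 1. Compound 3 (`COc1cc(/C=C2\CN(C)C/C(=C\c3ccc(C#N)cc3)C2=O)cc(OC)c1`) differs from compound 2 in one place, with cyano in place of fluoro on an aromatic carbon, para to a large group: cyano in place of fluoro on an aromatic carbon. Going by the values given here, no measured pair shows a single-place change, so the size of this step has no direct precedent. No step beyond the scatter is expected in this assay, in either direction. The estimate therefore stays close to compound 2 at 6140 nM. The expected step is a 1.0-fold lower number from compound 2 to compound 3 (0.01 log units; within the scatter). The estimate for compound 3 is 6000 nM, with an expected range of 2000 nM to 18000 nM.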

Compound 3, half-maximal inhibitory concentration: 880 nM
Beside the measured number, compound 3's estimate is 6.8-fold (0.83 log units) above it; measured number outside the range, below it.
By their numbers in this assay, from the lowest: compound 3; then compounds 2 and 1 (each within the scatter of the next).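

In this assay, going from 4-fluorophenyl to 4-cyanophenyl gives a 7.0-fold lower number from compound 2 to compound 3 (0.84 log units; beyond the scatter). Going by these compounds alone, this is the first single-place step, and it shows that the aromatic carbon para to a large group is sensitive to the group it carries, which compounds 1 and 2 alone could not show.

Going by these compounds, whether an amine or a carboxylic acid at this place would move the number in the same direction remains open. No measurement shown here accounts for the size of this step.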